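The source may report more compounds than this note shows. Statements on the series, on what has been measured and on what is new or still open speak of the compounds shown alone.

In an ADME assay on the whole organism (Rattus norvegicus), at a dose of 2 mg/kg by the oral route (on this read-out higher numbers stand for higher exposure at the dose given and lower numbers for lower exposure), compound 1 (`COc1cc(OCc2cccc(-c3ccc(OC)nc3)c2)c2cc(-c3cn4nc(OC)sc4n3)oc2c1`) gives 1800 ng.h/mL and stands second highest of three numbers, with compound 2 (`COc1cc(OCc2csc(-c3ccc(C(C)(C)O)cc3)n2)c2cc(-c3cn4nc(OC)sc4n3)oc2c1`) at 505 ng.h/mL and compound 3 (`COc1cc(OCc2csc(-c3ccccc3)n2)c2cc(-c3cn4nc(OC)sc4n3)oc2c1`) at 3920 ng.h/mL on the same read-out. Compound 4 (`COc1cc(OCc2cccc(OCc3ccccc3)c2)c2cc(-c3cn4nc(OC)sc4n3)oc2c1`) carries benzyloxy in place of 6-methoxypyridin-3-yl on an aromatic carbon. Going by the values given here, the only measured step (a 7.8-fold higher number from compound 2 to compound 3 (0.89 log units; beyond the scatter)) is a different exchange, hydrogen in place of 1-hydroxy-1-methylethyl, and it shows the size one change reached here without testing this one. No measurement tests the present exchange, so no step beyond the scatter is expected in this assay and the estimated change is small (a 1.2-fold lower number from compound 1 to compound 4 (0.08 log units; within the scatter)). Compound 4 is estimated at 1500 ng.h/mL with an expected range from 500 ng.h/mL to 4500 ng.h/mL on that read-out.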

Compound 4, area under the concentration-time curve: 339 ng.h/mL
Compound 4: middle estimate off by 4.4-fold (0.65 log units), on the high side, and the stated range ends above it.
By their numbers in this assay, from the lowest: compounds 4 and 2 (each within the scatter of the next); then compound 1; then compound 3.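

In this assay the exchange of 6-methoxypyridin-3-yl for benzyloxy gives a 5.3-fold lower number from compound 1 to compound 4 (0.73 log units; beyond the scatter), so at this place on the aromatic carbon, meta to a large group, the number depends on the group carried, although both groups hold the same count of heavy atoms and one six-membered aromatic ring each. No measurement at hand says why the number fell. The compounds shown leave open how a simple phenyl, an amine or a carboxylic acid would fare at this place, and whether the same exchange would move the number similarly with the thiazole-bearing compounds.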